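A few compounds are considered here, and "the series" means these few. Any claim that something is new, unique, unknown or untested is made for them only; others in the source may bear on it.

Measured so far:
compound 1 `COc1cccc(CCOc2ccc(-c3c(C)nc(C)c([C@H](OC(C)(C)C)C(=O)O)c3N3CCC(C)(C)CC3)cc2)c1` — > 2 h
compound 2 `Cc1nc(C)c([C@H](OC(C)(C)C)C(=O)O)c(N2CCC(C)(C)CC2)c1-c1ccc(SCCc2ccc(F)cc2)cc1` — > 2 h

In an ADME assay on microsomes from liver (Rattus norvegicus) for metabolic stability, read by LC-MS, tested at 0.5 uM (a lower number here means that the compound disappears faster, a higher number that the compound lasts longer), compound 1 gives > 2 h, which is a limit and not a number. In this assay compound 2 likewise gives only a limit, > 2 h. The step that the two limits leave unreadable from compound 1 to compound 2 is accordingly not readable in size or direction. Compound 3 `Cc1nc(C)c(CCOc2ccc(-c3c(C)nc(C)c([C@H](OC(C)(C)C)C(=O)O)c3N3CCC(C)(C)CC3)cc2)s1` differs from compound 1 by 2,4-dimethyl-1,3-thiazol-5-yl in place of 3-methoxyphenyl on a saturated chain carbon, two bonds along the chain from an oxygen on an aromatic ring. Within the data shown here, no measured step bears on this change; the only evidence is the limit of > 2 h in this assay, at which 2 of the 2 values shown sit. Compound 3 is therefore expected to remain at that limit, with an estimated step that the limit leaves unreadable from compound 1 to compound 3. The estimate for compound 3 is 2.5 h, between 1 h and 6 h.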

Compound 3, half-life: > 2 h
Compound 3 gave a limit, no number; the forecaster's own chance of this, stated with the estimate: 70%; the middle value lies beyond the limit too.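

In this assay compound 3 gives > 2 h, a limit and not a number. Among these compounds, no step among compound 1, compound 2 and compound 3 can be read. The compounds shown leave open each compound's actual half-life and whether these changes alter it at all.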